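Pyrimidin-2-yl in place of 2-fluorophenyl on the shared core

The source may report more compounds than this note shows. Statements on the series, on what has been measured and on what is new or still open speak of the compounds shown alone.

Measured in a functional assay on HT-29 cells (Homo sapiens) for antiproliferative activity, read by MTT assay, with a stated time of 72 h; on this read-out higher numbers stand for weaker inhibition and lower numbers for stronger inhibition:
- Compound 1 `Nc1nc(N)c2cc(CSC(=S)N3CCN(c4ccc(Cl)c(Cl)c4)CC3)ccc2n1`: 3480 nM
- Compound 2 `Nc1nc(N)c2cc(CSC(=S)N3CCN(c4ccccc4F)CC3)ccc2n1`: 5420 nM

Going by the values given here, only two compounds have numbers so far, and compound 2 stands within the scatter of compound 1, its sole neighbour. Compound 3 `Nc1nc(N)c2cc(CSC(=S)N3CCN(c4ncccn4)CC3)ccc2n1` keeps the shared core and changes one group: pyrimidin-2-yl in place of 2-fluorophenyl on an amine nitrogen in a ring. Pyrimidin-2-yl thus takes the place of 2-fluorophenyl on an amine nitrogen in a ring.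

Among the compounds with values here, one measured step bears on this change, as it concerns the same place: a 1.6-fold higher number from compound 1 to compound 2 (0.19 log units; within the scatter). Within the data shown here, it exchanged one aromatic ring of carbon only for another, however, and no measured compound carries a ring with hetero atoms there, so the evidence is thin. On the strength of that single step, no change beyond the scatter is expected in this assay, and neither direction is favoured. The estimated change is a 1.0-fold higher number from compound 2 to compound 3 (0.01 log units; within the scatter). Compound 3 is expected at about 5500 nM, with an estimated range of 1900 nM to 16000 nM.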

Compound 3, half-maximal inhibitory concentration: 4720 nM
Compound 3: middle estimate off by 1.2-fold (0.07 log units), on the high side, within the range that was stated.
By their numbers in this assay, from the lowest: compounds 1, 3 and 2 (each within the scatter of the next).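

In this assay, the place on the amine nitrogen in the ring now includes a measured aromatic ring with hetero atoms, and pyrimidin-2-yl in place of 2-fluorophenyl gives (a 1.1-fold lower number from compound 2 to compound 3 (0.06 log units; within the scatter)). Against the 3,4-dichlorophenyl group, the same ring gives (a 1.4-fold higher number from compound 1 to compound 3 (0.13 log units; within the scatter)), so all three groups at this place, two rings of carbon only and one with 2 hetero atoms, lie within the scatter of one another. Thus, among these three compounds, neither the hetero atoms of pyrimidin-2-yl nor its 2 hydrogen-bond acceptors go with a difference that can be told from the scatter, and no measurement at hand gives a reason for this result.

The compounds shown leave open whether a group without an aromatic ring on this nitrogen, such as an acetyl group or a short alkyl chain, would stand apart from these three in this read-out. They also leave open whether a benzyl group, which would set a carbon atom between the nitrogen and the aromatic ring, or a pyridin-2-yl ring would fall within the same scatter.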